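A few compounds are considered here, and "the series" means these few. Any claim that something is new, unique, unknown or untested is made for them only; others in the source may bear on it.

Among the measured compounds shown here, in a functional assay on PC-3 cells (Homo sapiens) for antiproliferative activity, read by MTT assay, with a stated time of 72 h (a lower number here means a stronger inhibitor, a higher number a weaker inhibitor), compound 2 (`O=C(N/N=C/c1ccc(O)c(Br)c1)Nc1ccc(Oc2ccnc3[nH]ccc23)c(F)c1`) gives 28600 nM, the higher of the two numbers so far, while compound 1 (`O=C(N/N=C/c1ccc(Br)cc1)Nc1ccc(Oc2ccnc3[nH]ccc23)c(F)c1`) gives 920 nM. Compound 3 (`O=C(N/N=C/c1cc(Br)c(O)c(Br)c1)Nc1ccc(Oc2ccnc3[nH]ccc23)c(F)c1`) has bromo in place of hydrogen on an aromatic carbon, ortho to the hydroxy group: bromo in place of hydrogen on an aromatic carbon. For the measured compounds named here, the one measured step, a 31-fold higher number from compound 1 to compound 2 (1.49 log units; beyond the scatter), is large but makes a different change on this ring, so it shows only that the number can move far there. A moderate step toward a lower number is therefore expected, a 2.0-fold lower number from compound 2 to compound 3 (0.31 log units; beyond the scatter). For compound 3 the expected value is 14000 nM, with an estimated range from 3500 nM to 50000 nM.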

Compound 3, half-maximal inhibitory concentration: "not active" (no number reported)
Compound 3 has no reported number here; there is nothing to compare the estimate with.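

Compound 3 is recorded as not active, with no number, so no step from compound 2 to compound 3 can be read, and nothing measured here offers an explanation. The compounds shown leave open how far the change to 3,5-dibromo-4-hydroxyphenyl moves the number.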